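Phenoxy for 4-fluorophenyl in a series at the limit

The compounds below may be only part of what the source reports. "The series", "measured", "known", "first", "only" and "open" are said of these compounds alone.

In an ADME assay on MRC5 cells (Homo sapiens) for cytotoxicity, read by fluorescence and resazurin assay, with a stated time of 3 days (a lower number here means that less compound is tolerated, a higher number that more compound is tolerated), compound 1 `N#Cc1ccc(C2CCN(C(=O)Nc3cc(-c4ccccn4)n[nH]3)CC2)cc1` gives > 64000 nM, which is a limit of the assay and not a number. Compound 2 `O=C(Nc1cc(-c2ccccn2)n[nH]1)N1CCC(c2ccc(F)cc2)CC1` gives > 64000 nM, likewise a limit. The series therefore has no numerical value yet, and the limit of > 64000 nM in this assay, at which 2 of the 2 values shown sit, sums up the position.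

Compound 3 `O=C(Nc1cc(-c2ccccn2)n[nH]1)N1CCC(Oc2ccccc2)CC1` differs from compound 2 at one place: phenoxy in place of 4-fluorophenyl on a saturated ring carbon. The phenoxy group brings an oxygen in place of the fluorine count on the leaving group, and it adds a hydrogen-bond acceptor.

Among the measured compounds shown here, the one measured step is a step that the two limits leave unreadable from compound 1 to compound 2, a change of fluoro for cyano on an aromatic carbon. It gives no size to carry over and it concerns a different part of the structure, so it offers only weak guidance. Neither compound 1 nor compound 2 has shown a cytotoxic concentration within the range of this assay, so no step beyond the scatter is expected, and no direction is favoured.

The expected change is an at least 1.0-fold lower number from compound 2 to compound 3 (0.02 log units; that floor lies within the scatter). Compound 3 is estimated at 60000 nM, with an expected range of 25000 nM to 64000 nM, and most likely a limit again.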

Compound 3, half-maximal cytotoxic concentration: > 64000 nM
Compound 3 was reported as a limit (the forecaster's own chance of this, stated with the estimate: 80%); at least 1.0-fold (0.02 log units) between middle value and limit.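

In this assay compound 3 gives > 64000 nM, which is again a limit of the assay and not a number. The steps among compound 1, compound 2 and compound 3 therefore cannot be read. The compounds shown leave open whether 4-cyanophenyl, 4-fluorophenyl or phenoxy makes any difference to the half-maximal cytotoxic concentration.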